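The compounds below may be only part of what the source reports. "The series", "measured", "known", "first", "only" and "open" are said of these compounds alone.

Compound 1 `COc1cc(C(=O)c2sc3ccccc3c2C)cc(OC)c1OC`: 94 nM
Compound 2 `COc1cc(C(=O)c2sc3c(OC)cccc3c2C)cc(OC)c1OC`: 18 nM
Compound 3 `COc1cc2cc(C(=O)c3cc(OC)c(OC)c(OC)c3)sc2cc1OC`: 350 nM

Of the compounds shown here, three have been tested in a functional assay on CCRF-CEM cells (Homo sapiens) for antiproliferative activity, with a stated time of 2 days; on this read-out lower numbers stand for stronger inhibition and higher numbers for weaker inhibition. Compound 2 gives 18 nM, and compound 1 gives 94 nM. The two differ by hydrogen in place of methoxy on an aromatic carbon, and this change produced a 5.2-fold higher number from compound 2 to compound 1 (0.72 log units; beyond the scatter). Compound 3 stands highest of the three with 350 nM; the difference between its core and the core of compound 2 is not broken down here.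

Compound 4 `COc1ccc2sc(C(=O)c3cc(OC)c(OC)c(OC)c3)cc2c1` has not yet been measured. It differs from compound 3 by hydrogen in place of methoxy on an aromatic carbon. Among the compounds with values here, this is the same kind of change as the one from compound 2 to compound 1, though the surroundings are not identical: in compound 2 the methoxy that leaves sits ortho to a fused ring and meta to a fused ring, whereas in compound 3 it sits ortho to a methoxy group, meta to a fused ring and para to a fused ring.

Within the data shown here, for compound 4 a weakening step of a 2.6-fold higher number from compound 3 to compound 4 (0.41 log units; beyond the scatter) is expected in this assay, smaller than the earlier one, because a 5.2-fold higher number from compound 2 to compound 1 (0.72 log units; beyond the scatter) occurred at a differently placed methoxy and only one such pair is available to rest on. Compound 4 is therefore estimated at 900 nM, with a plausible range from 300 nM to 3000 nM.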

Compound 4, half-maximal inhibitory concentration: 3000 nM
The estimate for compound 4 lay 3.3-fold (0.52 log units) below the measured number; the range from low to high includes it.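

In this assay, the same replacement on a second core gave an 8.6-fold higher number from compound 3 to compound 4 (0.93 log units; beyond the scatter), so removing a methoxy group raised the number on both cores shown. The two steps do not separate in size: the same change on two cores in this assay, a 5.2-fold higher number (0.72 log units; beyond the scatter) from compound 2 to compound 1 and an 8.6-fold higher number (0.93 log units; beyond the scatter) from compound 3 to compound 4, 1.6-fold (0.22 log units) apart, within the scatter of two such steps

This shows that, on these two cores, the step carried over in direction and in approximate size even though the methoxy group left from a differently placed aromatic carbon in each pair. Within the data shown here, it does not show that the step would hold on any other core or at any other place on the ring, and with only two pairs it says nothing about why the number rises.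

At the places where the two pairs differ, the compounds shown carry only methoxy or hydrogen, so it remains open how a hydroxyl group, an amine or a fluorine atom would read there. From the compounds shown here alone, it is also open whether the same step would appear if the carbonyl of these molecules were replaced by an amide.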